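This account rests on a few compounds, and the source may have more. Where it says the series, first, only, none or still open, it means among the compounds named here.

In a functional assay on MIA PaCa-2 cells (Homo sapiens) for cytotoxicity, read by MTT assay, with a stated time of 72 h (on this read-out higher numbers stand for weaker inhibition and lower numbers for stronger inhibition), compound 1 (`Nc1ccc(-c2ccc(NC3=CC(=O)c4ncncc4C3=O)cc2)cc1`) gives 2500 nM. This places it among its two measured relatives with no separation beyond the scatter: compound 2 (`COc1ccc(-c2ccc(NC3=CC(=O)c4ncncc4C3=O)cc2)cc1`) gives 2100 nM and compound 3 (`O=C1C(Nc2ccc(-c3ccc(F)cc3)cc2)=CC(=O)c2ncncc21`) gives 3500 nM. The next compound, compound 4 (`NS(=O)(=O)c1ccc(NC2=CC(=O)c3ncncc3C2=O)cc1`), departs much further from compound 1: sulfamoyl in place of 4-aminophenyl on an aromatic carbon. In short, sulfamoyl stands in place of 4-aminophenyl on an aromatic carbon. The three measured steps, a 1.2-fold lower number from compound 1 to compound 2 (0.08 log units; within the scatter), a 1.4-fold higher number from compound 1 to compound 3 (0.15 log units; within the scatter) and a 1.7-fold higher number from compound 2 to compound 3 (0.22 log units; within the scatter), all stay within the scatter. Each of them only exchanges amino, methoxy or fluoro on an aromatic carbon and keeps the ring that compound 4 lacks, so they bear on this change only loosely. For the measured compounds named here, no measured compound shows the loss of that ring, and the direction is therefore a cautious expectation of a higher number in this assay. The expected change is a 2.4-fold higher number from compound 1 to compound 4 (0.38 log units; beyond the scatter), with wide uncertainty. For compound 4 the estimated value is 6000 nM, with an expected range from 1800 nM to 20000 nM.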

Compound 4, half-maximal inhibitory concentration: > 10000 nM
Compound 4: no number, only a limit; the forecaster's own chance of this, stated with the estimate: 12%; middle value at least 1.6-fold (0.22 log units) from the limit.
By their numbers in this assay, from the lowest: compounds 2, 1 and 3 (each within the scatter of the next). At a limit, above all of these: compound 4.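

In this assay compound 4 gives only a limit, not a number: the limit of > 10000 nM in this assay, at which 1 of the 4 values shown sits.

Even so, sulfamoyl in place of the ring-bearing group is the first change here to go beyond the scatter, with an at least 4.0-fold higher number from compound 1 to compound 4 (0.60 log units; beyond the scatter), an at least 2.8-fold higher number from compound 3 to compound 4 (0.45 log units; beyond the scatter) and an at least 4.7-fold higher number from compound 2 to compound 4 (0.67 log units; beyond the scatter). Amino, methoxy and fluoro on that six-membered aromatic ring left the numbers within the scatter of each other, so among these four compounds the exchange of the whole group counts for more at this position than the exchange of the small group on the ring.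

As far as these compounds go, how far the true value of compound 4 lies past its limit stays open. Also open, from the compounds shown here alone, is whether the loss of the ring or the entry of sulfamoyl carries the change, and how an amine or a carboxylic acid on the same aromatic carbon would read.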